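Pyrazole chalcones against U-251 cells: varying the aryl ketone

The source may report more compounds than this note shows. Statements on the series, on what has been measured and on what is new or still open speak of the compounds shown alone.

Measured so far:
- compound 1 `COc1cc(-c2cc(/C=C/C(=O)c3ccc(Cl)c(Cl)c3)[nH]n2)cc(OC)c1OC`: -5%
- compound 2 `COc1ccc(-c2cc(/C=C/C(=O)c3ccc(N)cc3)[nH]n2)cc1OC`: -96%
- compound 3 `COc1ccc(-c2cc(/C=C/C(=O)c3cc(OC)c(OC)c(OC)c3)[nH]n2)cc1OC`: -94%

In a functional assay on U-251 cells (Homo sapiens) for cytotoxicity, read by sulforhodamine B assay, with a stated time of 48 h, tested at 100 uM (on this read-out lower numbers stand for a stronger effect and higher numbers for a weaker effect at the one concentration tested), compound 1 gives -5%, the highest of the three numbers. For the measured compounds named here, compound 3 sits far below it, and compound 2 further still, both gaps beyond the scatter; no single-change step between these three is available, so only the values themselves are compared.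

Compound 4 `COc1ccc(C(=O)/C=C/c2cc(-c3cc(OC)c(OC)c(OC)c3)n[nH]2)cc1OC` is the next candidate. It differs from compound 1 in one place: 3,4-dimethoxyphenyl in place of 3,4-dichlorophenyl on a carbonyl carbon

Compounds 2 and 3, which carry other aryl groups on the carbonyl carbon, give low numbers. On that basis a large downward step is expected, estimated as a number 75 percentage points lower from compound 1 to compound 4 (beyond the scatter). Compound 4 is expected to give about -80% in this assay, plausibly between -100% and -30%.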

Compound 4, a percentage reported as activity, at one concentration (the size of the read-out at that concentration, not a potency): -99%
For compound 4 the middle estimate is 19 percentage points above the measured one; low and high end bracket the measured number.
By their numbers in this assay, from the lowest: compounds 4, 2 and 3 (each within the scatter of the next); then compound 1.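

In this assay, for the compounds shown here, 3,4-dimethoxyphenyl in place of 3,4-dichlorophenyl on a carbonyl carbon gives a number 94 percentage points lower from compound 1 to compound 4 (beyond the scatter), the first single-change step. It shows that, with the rest of compound 1 held fixed, this one position is enough to move the read-out across nearly its whole observed range. Nothing available explains why this change acts so strongly.

Still open, on these data alone, is whether the step follows the loss of the chlorines or the arrival of the methoxy groups. A plain phenyl at this position would help separate the two.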